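Reversing the furan step: a methoxyphenyl hydrazone

A few compounds are considered here, and "the series" means these few. Any claim that something is new, unique, unknown or untested is made for them only; others in the source may bear on it.

Compound 1, `Cc1c(C(=O)N/N=C\c2cccc(O)c2O)oc2cccc(O)c12`, gives 12200 nM in a functional assay on PC-3 cells (Homo sapiens) for inhibition; on this read-out higher numbers stand for weaker inhibition and lower numbers for stronger inhibition.
Compound 2, `Cc1c(C(=O)N/N=C\c2c(O)cccc2Cl)oc2cccc(O)c12`, gives 18700 nM in this assay.
Compound 3, `Cc1c(C(=O)N/N=C\c2ccco2)oc2cccc(O)c12`, reaches only the assay limit >= 40000 nM in this assay.

Compound 3 thus stands at the weak end of the three, and its entry is a limit rather than a number (the limit of >= 40000 nM in this assay, at which 1 of the 3 values shown sits). Two measured steps lead into it: an at least 3.2-fold higher number from compound 1 to compound 3 (0.51 log units; beyond the scatter) and an at least 2.1-fold higher number from compound 2 to compound 3 (0.33 log units; beyond the scatter). Both replace a six-membered carbon ring by furan-2-yl, and both raise the number beyond the scatter.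

Compound 4, `COc1cccc(/C=N\NC(=O)c2oc3cccc(O)c3c2C)c1`, takes the opposite route: 3-methoxyphenyl in place of furan-2-yl on a carbon with a double bond to nitrogen. A six-membered carbon ring returns, though the 3-methoxyphenyl of compound 4 is neither the 2,3-dihydroxyphenyl of compound 1 nor the 2-chloro-6-hydroxyphenyl of compound 2. Since both measured steps onto furan-2-yl went up, the step back off it is expected to go down, with the size uncertain because compound 3 is only a limit. The expected step is an at least 2.0-fold lower number from compound 3 to compound 4 (0.30 log units; that floor lies within the scatter). Compound 4 is therefore estimated at 20000 nM, between 8000 nM and 60000 nM.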

Compound 4, half-maximal inhibitory concentration: >= 40000 nM
Compound 4: no number, only a limit (the forecaster's own chance of this, stated with the estimate: 30%); middle value at least 2.0-fold (0.30 log units) away from the limit.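

In this assay, putting 3-methoxyphenyl in place of furan-2-yl on a carbon with a double bond to nitrogen yields no number: compound 4 gives >= 40000 nM, which is a limit of the assay. Among the compounds shown here, the steps into it are an at least 2.1-fold higher number from compound 2 to compound 4 (0.33 log units; beyond the scatter) and an at least 3.2-fold higher number from compound 1 to compound 4 (0.51 log units; beyond the scatter), so at this place a six-membered carbon ring does not by itself return the activity of compound 1 and compound 2, the only two here with a number, and both of their rings carry a hydroxyl. The step from compound 3 to compound 4 cannot be read, and the two share one limit: the limit of >= 40000 nM in this assay, at which 2 of the 4 values shown sit.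

From the compounds shown here alone, the order of furan-2-yl and 3-methoxyphenyl therefore stays open. So does whether a single hydroxyl on the phenyl ring is enough, or whether an amine or a carboxylic acid in place of the methoxy group would bring a measurable value.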